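A headgroup swap on the four-carbon chain of compound 3

A few compounds are considered here, and "the series" means these few. Any claim that something is new, unique, unknown or untested is made for them only; others in the source may bear on it.

Compound 3 `C=CCNC(=S)NCCCCn1nc(-c2ccccc2)ccc1=O` gives 27.1% in a functional assay on the whole organism with Rattus norvegicus as the target, at a dose of 100 mg/kg (on this read-out higher numbers stand for more inhibition at the one dose given (going by the name of the read-out) and lower numbers for less inhibition), the second highest of the three numbers: compound 1 `C/N=C(/NC#N)NCCCn1nc(-c2ccccc2)ccc1=O` gives 40.5%, and compound 2 `CC/N=C(\S)NCCCCCCn1nc(-c2ccccc2)ccc1=O` gives -5.6%. Compound 4 `C/N=C(\NC#N)NCCCCn1nc(-c2ccccc2)ccc1=O` differs from compound 3 by a group of 6 heavy atoms (3 carbon, 3 nitrogen; no ring) in place of a group of 6 heavy atoms (4 carbon, 1 nitrogen, 1 sulfur; no ring), on an amine nitrogen. Going by the values given here, two measured steps bear on this change. The step of a number 13.4 percentage points lower from compound 1 to compound 3 (beyond the scatter) moved away from a headgroup of the kind that enters here, together with a chain change. The step of a number 32.7 percentage points higher from compound 2 to compound 3 (beyond the scatter) altered the same headgroup position with a chain change as well. Since compound 1 carries the entering group and gives 40.5%, compound 4 is expected to land near it, with a modest upward step a number 10.9 percentage points higher from compound 3 to compound 4 (beyond the scatter). Compound 4 is therefore estimated at 38%, within 22% to 54%.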

Compound 4, a percentage reported as inhibition, in the whole organism at one dose (the size of the read-out at that dose, not a potency): 79%
Estimate against measurement, compound 4: 41 percentage points below; measured number outside the range, above it.
By their numbers in this assay, from the lowest: compound 2; then compound 3; then compound 1; then compound 4.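

In this assay, the headgroup swap on the amine nitrogen, with the chain unchanged, gives a number 51.9 percentage points higher from compound 3 to compound 4 (beyond the scatter), so this change alone carries a large step. The chain matters too: with the headgroup kept, a number 38.5 percentage points higher from compound 1 to compound 4 (beyond the scatter), so compound 1 did not mark the upper end for this headgroup. The widest step in the set is a number 84.6 percentage points higher from compound 2 to compound 4 (beyond the scatter), where headgroup and chain change together.

Nothing here gives a reason for these steps. As far as these compounds go, how a urea headgroup would compare on the chain of compound 4 remains open.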